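Swapping a cyclohexyl for an oxanyl ring on the amide nitrogen

A few compounds are considered here, and "the series" means these few. Any claim that something is new, unique, unknown or untested is made for them only; others in the source may bear on it.

Measured compounds:
Compound 1 `O=C(CN(C(=O)c1ccc(-n2ccnc2)cc1)C1CCCCC1)Nc1cc(F)cc(F)c1` gives 631 nM in an assay on HEK293 cells for inhibition of sodium- and chloride-dependent glycine transporter 1 (Homo sapiens), read by scintillation proximity assay; on this read-out lower numbers stand for stronger inhibition and higher numbers for weaker inhibition.
Compound 2 `O=C(CN(C(=O)c1ccc(N2CCCC2)cc1)C1CCCCC1)Nc1cc(F)cc(F)c1` gives 79.4 nM in this assay.
Compound 3 `O=C(CN(C(=O)c1ccc(-c2ccccn2)cc1)C1CCCCC1)Nc1cc(F)cc(F)c1` gives 63.1 nM in this assay.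

Compound 3 has the lowest number of the three; the step of a 10-fold lower number from compound 1 to compound 3 (1.00 log units; beyond the scatter) lies beyond the scatter, while the step of a 1.3-fold lower number from compound 2 to compound 3 (0.10 log units; within the scatter) does not, so compound 3 and compound 2 cannot be ranked against each other. Compound 4 `O=C(CN(C(=O)c1ccc(-c2ccccn2)cc1)C1CCCOC1)Nc1cc(F)cc(F)c1` differs from compound 3 by oxan-3-yl in place of cyclohexyl on an amide-type nitrogen. Going by the values given here, none of the measured steps concerns this position; all three change the group on the aromatic carbon. Among the compounds with values here, with no step to lean on, compound 4 is expected to sit near compound 3, with a change of a 1.6-fold higher number from compound 3 to compound 4 (0.20 log units; within the scatter) in this assay that need not exceed the scatter. The estimate for compound 4 is 100 nM, with a range from 30 nM to 320 nM.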

Compound 4, half-maximal inhibitory concentration: 79.4 nM
Beside the measured number, compound 4's estimate is 1.3-fold (0.10 log units) above it, and the stated range covers the measured number.
By their numbers in this assay, from the lowest: compounds 3, 2 and 4 (each within the scatter of the next); then compound 1.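

Going by these compounds alone, compounds 1 to 3 varied only the group on the aromatic carbon, so this is the first reading at the amide-type nitrogen. In this assay, oxan-3-yl in place of cyclohexyl gives a 1.3-fold higher number from compound 3 to compound 4 (0.10 log units; within the scatter), so bringing one ring oxygen and its hydrogen-bond acceptor into this ring produces no readable change for this pair. No evidence here explains this result. On these data alone, it remains open whether an amine in the ring, as in piperidin-3-yl, or a smaller ring such as cyclopentyl, would fare alike. As far as these compounds go, whether the same swap holds with pyrrolidin-1-yl on the aromatic carbon is also open.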